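A few compounds are considered here, and "the series" means these few. Any claim that something is new, unique, unknown or untested is made for them only; others in the source may bear on it.

Compounds measured so far in a functional assay on CCRF-CEM cells for agonist activity at C-X-C chemokine receptor type 4 (Homo sapiens), read by calcium flux, with a stated time of 25 min; a lower number here means that less compound is needed, a higher number that more compound is needed for the effect:
- compound 1 `CN1CCN(c2cccc3c2C[C@H](CN(C)[C@H]2CCCc4cccnc42)NC3)CC1`: > 30000 nM
- compound 2 `CN(C[C@H]1Cc2c(cccc2N2CCNCC2)CN1)[C@H]1CCCc2cccnc21`: > 30000 nM

Both numbers are limits of this assay, not measured values. Compound 1 gives > 30000 nM, a limit. Compound 2 gives > 30000 nM, likewise a limit. Among the compounds with values here, the one step between measured compounds, a step that the two limits leave unreadable from compound 1 to compound 2, is therefore unreadable in size and direction; all that is known is the limit of > 30000 nM in this assay, at which 2 of the 2 values shown sit. Compound 1 thus stands at the limit of this assay, with no number to place it.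

Compound 3 `CN1CCN(c2cccc3c2C[C@H](CN(C)[C@H]2CCCc4cccnc42)N(C)C3)CC1` differs from compound 1 by methyl in place of hydrogen on an amine nitrogen in a ring. Within the data shown here, no measured step bears directly on this change: the step from compound 1 to compound 2 concerns a different ring amine nitrogen and is itself unreadable. There is no evidence for a step in either direction, and the shown values give no foothold for a number. The expectation for compound 3 is therefore that it also sits at the limit of this assay, with an estimated step of a number no higher from compound 1 to compound 3 (the limit leaves the size open) that cannot be distinguished from none. Compound 3 is accordingly estimated at 30000 nM, within a range of 10000 nM to 100000 nM.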

Compound 3, half-maximal effective concentration: > 30000 nM
Compound 3: no number, only a limit (the forecaster's own chance of this, stated with the estimate: 80%); the middle value lies on the limit itself.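

No step can be read from compound 1 to compound 3, since both values are limits of this assay, and the same holds for compound 2: the limit of > 30000 nM in this assay, at which 3 of the 3 values shown sit. The compounds shown leave open how far any of the three lies from that limit, and whether either change on a ring amine nitrogen alters the response at all.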